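This account rests on a few compounds, and the source may have more. Where it says the series, first, only, none or still open, it means among the compounds named here.

Measured compounds:
Compound 1 `CCOc1cc(C2CCN(C)CC2)ccc1Nc1ncc2c(n1)N(Cc1sccc1C)[C@H](CC)C(=O)N2C` in an assay on isolated protein for inhibition of serine/threonine-protein kinase PLK1 (Homo sapiens), read by Z'-LYTE, with a stated time of 60 min (a lower number here means a stronger inhibitor, a higher number a weaker inhibitor), gives 68 nM.
Compound 2 `CCOc1cc(C2CCN(C)CC2)ccc1Nc1ncc2c(n1)N(Cc1ccccc1)[C@H](CC)C(=O)N2C` in this assay gives 290 nM.
Compound 3 `CCOc1cc(C2CCN(C)CC2)ccc1Nc1ncc2c(n1)N(Cc1ccccc1Br)[C@H](CC)C(=O)N2C` in this assay gives "not determined" (no result reported), that is, no result.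

Compound 3 therefore stands nowhere on the numbers shown. Compound 4 `CCOc1cc(C2CCN(C)CC2)ccc1Nc1ncc2c(n1)N(Cc1cccc(Br)c1)[C@H](CC)C(=O)N2C` differs from it in one place: 3-bromophenyl in place of 2-bromophenyl on a saturated chain carbon bound to a nitrogen on an aromatic ring in a ring. For the measured compounds named here, no measured step bears on this change directly; the only step, a 4.3-fold higher number from compound 1 to compound 2 (0.63 log units; beyond the scatter), alters the group on the same saturated chain carbon but exchanges different groups, and it was modest. The data hold nothing on a bromine moved around the phenyl, so no size or direction of step beyond the scatter is expected for compound 4. Compound 4 is estimated to lie near the benzyl compound 2, at 200 nM, within 50 nM to 800 nM.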

Compound 4, half-maximal inhibitory concentration: 540 nM
Compound 4: middle estimate off by 2.7-fold (0.43 log units), on the low side; low and high end bracket the measured number.
By their numbers in this assay, from the lowest: compound 1; then compounds 2 and 4 (each within the scatter of the next).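

In this assay, the result gives a 1.9-fold higher number from compound 2 to compound 4 (0.27 log units; within the scatter), so on this saturated chain carbon, bromo in place of hydrogen on an aromatic carbon does not separate 3-bromophenyl from plain phenyl. The other step, a 7.9-fold higher number from compound 1 to compound 4 (0.90 log units; beyond the scatter), leaves 3-bromophenyl apart from 3-methylthiophen-2-yl, as phenyl was. Nothing shown bears on why the numbers fall this way. From the compounds shown here alone, the step from compound 3 cannot be read, so moving the bromine from 2-bromophenyl to 3-bromophenyl stays open, as does whether a methoxy group or an amine in place of bromo would read differently.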